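Exchanging the Amine Substituent: Compound 3 to Compound 4

This account rests on a few compounds, and the source may have more. Where it says the series, first, only, none or still open, it means among the compounds named here.

Compound 1 `CCCCNc1nc(C(F)(F)F)ccc1CNC(=O)C(C)c1ccc(NS(C)(=O)=O)c(F)c1`: 9.1 nM
Compound 2 `CC1CCC(Nc2nc(C(F)(F)F)ccc2CNC(=O)C(C)c2ccc(NS(C)(=O)=O)c(F)c2)CC1`: 27.2 nM
Compound 3 `CC(C(=O)NCc1ccc(C(F)(F)F)nc1Nc1ccc(F)cc1)c1ccc(NS(C)(=O)=O)c(F)c1`: 39.2 nM

In a functional assay on CHO-K1 cells for antagonist activity at transient receptor potential cation channel subfamily V member 1 (Homo sapiens), read by FLIPR (on this read-out lower numbers stand for stronger inhibition and higher numbers for weaker inhibition), compound 3 gives the highest of the three numbers; compound 2 lies within the scatter of it, whereas a 4.3-fold higher number from compound 1 to compound 3 (0.63 log units; beyond the scatter) is beyond the scatter. Compound 4 `CC(C(=O)NCc1ccc(C(F)(F)F)nc1N1CCC(c2ccccc2)CC1)c1ccc(NS(C)(=O)=O)c(F)c1` differs from compound 3 in one place: 4-phenylpiperidin-1-yl in place of (4-fluorophenyl)amino on an aromatic carbon. Going by the values given here, no measured step covers this exact exchange. The closest comparisons are a 3.0-fold higher number from compound 1 to compound 2 (0.48 log units; beyond the scatter) and a 4.3-fold higher number from compound 1 to compound 3 (0.63 log units; beyond the scatter), both modest, and a 1.4-fold higher number from compound 2 to compound 3 (0.16 log units; within the scatter), within the scatter. The change to compound 4 is larger than any of these, so a modest rise in the number is expected, a 2.0-fold higher number from compound 3 to compound 4 (0.31 log units; beyond the scatter). Compound 4 is therefore estimated at 80 nM, with a range from 20 nM to 320 nM.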

Compound 4, inhibition constant: 0.6 nM
The estimate for compound 4 lay 130-fold (2.12 log units) above the measured number; measured number below the stated range.
By their numbers in this assay, from the lowest: compound 4; then compound 1; then compounds 2 and 3 (each within the scatter of the next).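

In this assay, putting 4-phenylpiperidin-1-yl on this aromatic carbon gives a 65-fold lower number from compound 3 to compound 4 (1.82 log units; beyond the scatter), a 45-fold lower number from compound 2 to compound 4 (1.66 log units; beyond the scatter) and a 15-fold lower number from compound 1 to compound 4 (1.18 log units; beyond the scatter), all large, whereas the steps among the three amino groups were modest or within the scatter. Among the compounds shown, only compound 4 has no hydrogen-bond donor in this substituent. Nothing available explains the drop in the number.

The compounds shown leave open whether the result follows from the loss of that donor or from the piperidine with its phenyl. Plain piperidin-1-yl or 4-benzylpiperidin-1-yl at this place would bear on that question.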